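This account rests on a few compounds, and the source may have more. Where it says the series, first, only, none or still open, it means among the compounds named here.

Compound 1 `CCn1c(C(=O)NCCCN(C)C)ccc1C(CC)(CC)c1ccc(OCCC(O)(CC)CC)c(C)c1`: 2420 nM
Compound 2 `C=CCN(C)C(=O)c1ccc(C(CC)(CC)c2ccc(OCCC(O)(CC)CC)c(C)c2)n1CC`: 1190 nM
Compound 3 `CCn1c(C(=O)Nc2ccc(OC(F)(F)F)cc2)ccc1C(CC)(CC)c1ccc(OCCC(O)(CC)CC)c(C)c1`: > 50000 nM (a limit of the assay, not a number)

In an ADME assay on L02 cells (Homo sapiens) for antiproliferative activity, read by MTT assay, with a stated time of 48 h (a higher number here means a weaker inhibitor, a lower number a stronger inhibitor), compound 3 gives > 50000 nM, which is a limit and not a number.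

Both other compounds read well lower, so compound 3 is the weakest inhibitor of the three. Compound 4 `CCOC(=O)CN(C)C(=O)c1ccc(C(CC)(CC)c2ccc(OCCC(O)(CC)CC)c(C)c2)n1CC` has not yet been measured. It carries ((ethoxycarbonyl)methyl)(methyl)amino in place of (4-(trifluoromethoxy)phenyl)amino on a carbonyl carbon.

The closest guide is an at least 42-fold higher number from compound 2 to compound 3 (1.62 log units; beyond the scatter), a large step, and an at least 20-fold higher number from compound 1 to compound 3 (1.31 log units; beyond the scatter) is also large. Both involve adding the (4-(trifluoromethoxy)phenyl)amino group that compound 4 lacks. By contrast, a 2.0-fold lower number from compound 1 to compound 2 (0.31 log units; beyond the scatter) is modest. A large step towards a lower number is therefore expected, although neither compound 1 nor compound 2 carries the incoming group, so the range stays wide.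

The step is estimated as an at least 8.3-fold lower number from compound 3 to compound 4 (0.92 log units; beyond the scatter).

For compound 4 the expected value is 6000 nM, with an estimated range from 1500 nM to 35000 nM.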

Compound 4, half-maximal inhibitory concentration: 1990 nM
Compound 4: middle estimate off by 3.0-fold (0.48 log units), on the high side, within the range that was stated.
By their numbers in this assay, from the lowest: compounds 2, 4 and 1 (each within the scatter of the next, the first and the last beyond it). At a limit, above all of these: compound 3.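

In this assay, putting ((ethoxycarbonyl)methyl)(methyl)amino in place of (4-(trifluoromethoxy)phenyl)amino on the carbonyl carbon gives an at least 25-fold lower number from compound 3 to compound 4 (1.40 log units; beyond the scatter), so this position can move the reading a long way. The value for compound 3 is a limit, not a number: the limit of > 50000 nM in this assay, at which 1 of the 4 values shown sits. Compound 4 also falls in with the two earlier compounds that lack the aromatic ring, with a 1.7-fold higher number from compound 2 to compound 4 (0.22 log units; within the scatter) and a 1.2-fold lower number from compound 1 to compound 4 (0.08 log units; within the scatter), so ethoxycarbonyl in place of vinyl makes no clear difference, and this ester-bearing group reads like the (3-(dimethylamino)propyl)amino group.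

From the compounds shown here alone, whether the aromatic ring or its trifluoromethoxy group sets compound 3 apart remains open, and a plain phenylamino group would help to separate them. Going by these compounds, how a carboxylic acid in place of the ethyl ester would read in this assay also remains open.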